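Chloro in place of hydroxy on the oxindole portion of the series

The source may hold more compounds than are shown below. What is called first, only, known or untested is meant among the compounds shown, and "the series" means these compounds.

Compound 1 `COc1cc2c(/C=C3/C(=O)Nc4ccc(O)cc43)c(Cl)n(Cc3cc(OC)c(OC)c(OC)c3)c2cc1C` gives 50100 nM in a functional assay on cells (Cancer cell lines, Homo sapiens) for cytotoxicity, with a stated time of 48 h (on this read-out higher numbers stand for weaker inhibition of growth and lower numbers for stronger inhibition of growth), the highest of the two numbers recorded so far. Among the compounds with values here, compound 2 `COc1cc2c(/C=C3/C(=O)Nc4ccc(Cl)cc43)c(Cl)n(Cc3cc(OC)c(OC)c(OC)c3)c2cc1C` gives 3890 nM in this assay, and the step of a 13-fold lower number from compound 1 to compound 2 (1.11 log units; beyond the scatter) is the only measured change available. Compound 3 `COc1cc2c(/C=C3/C(=O)Nc4cccc(Cl)c43)c(Cl)n(Cc3cc(OC)c(OC)c(OC)c3)c2cc1C` is not yet measured; it differs from compound 1 by a group of 12 heavy atoms (9 carbon, 1 nitrogen, 1 oxygen, 1 chlorine; one five-membered non-aromatic ring with 1 hetero atom, one six-membered aromatic ring of carbon only) in place of a group of 12 heavy atoms (9 carbon, 1 nitrogen, 2 oxygen; one five-membered non-aromatic ring with 1 hetero atom, one six-membered aromatic ring of carbon only), on an aromatic carbon. The incoming group carries a chlorine where the departing group carries a hydroxy, as in the change from compound 1 to compound 2, so that step bears on the present one; the exact placement of the chlorine in compound 3 differs from that in compound 2 and no comparison is recorded for it. A lower number than that of compound 1 is therefore expected, because of a 13-fold lower number from compound 1 to compound 2 (1.11 log units; beyond the scatter), though of uncertain size. The estimated step is an 8.4-fold lower number from compound 1 to compound 3 (0.92 log units; beyond the scatter). For compound 3 the expected value in this assay is 6000 nM, within the range 2000 nM to 20000 nM.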

Compound 3, concentration for total growth inhibition: 5130 nM
Compound 3: the middle estimate sits 1.2-fold (0.07 log units) above what was measured; the measured number falls inside the stated range.
By their numbers in this assay, from the lowest: compounds 2 and 3 (each within the scatter of the next); then compound 1.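

In this assay, the gain on going from hydroxy to chloro is not tied to a single placement of the chlorine: the series shows a 9.8-fold lower number from compound 1 to compound 3 (0.99 log units; beyond the scatter) alongside the earlier step to compound 2. The two chloro-bearing groups differ only in where the chlorine stands, and the series shows a 1.3-fold higher number from compound 2 to compound 3 (0.12 log units; within the scatter) for that change, so these two placements cannot be told apart on this read-out. Nothing on hand accounts for either step.

Still open, as far as these compounds go, is whether chlorine itself matters or whether other groups at these places, such as a methoxy, an amine or a carboxylic acid, would give similar numbers. Also open, from the compounds shown here alone, is how a hydroxy at the place of the chlorine in compound 3 would compare, since compound 1 carries its hydroxy elsewhere.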